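A few compounds are considered here, and "the series" means these few. Any claim that something is new, unique, unknown or untested is made for them only; others in the source may bear on it.

The compounds measured so far:
Compound 1 `CCOC(=O)c1c(-c2cccc(C)c2)[nH]c2cc(OC)ccc2c1=O` reaches, in an ADME assay on Raji cells (Homo sapiens) for cytotoxicity, read by luminescence, with a stated time of 72 h (on this read-out higher numbers stand for an effect only at larger amounts of compound and lower numbers for an effect already at smaller amounts), only a limit of > 21500 nM.
Compound 2 `CCOC(=O)c1c(-c2cccc(OC)c2)[nH]c2cc(OC)ccc2c1=O` reaches in this assay only a limit of > 21500 nM.
Compound 3 `CCOC(=O)c1c(-c2cccc(OCC)c2)[nH]c2cc(OC)ccc2c1=O` reaches in this assay only a limit of > 21500 nM.

Compound 1 therefore stands at the limit of > 21500 nM in this assay, at which 3 of the 3 values shown sit, with no number of its own in this assay. The unmeasured compound 4 `CCOC(=O)c1c(-c2cccc(Oc3ccccc3)c2)[nH]c2cc(OC)ccc2c1=O` differs from compound 1 by phenoxy in place of methyl on an aromatic carbon. Among the compounds with values here, the steps that bear on a change at this aromatic carbon are a step that the two limits leave unreadable from compound 1 to compound 2, a step that the two limits leave unreadable from compound 1 to compound 3 and a step that the two limits leave unreadable from compound 2 to compound 3; none of them has a readable size, since every value involved is a limit. Within the data shown here, no measured step therefore gives a direction or size for compound 4 in this assay, and the expectation is that compound 4 stays in the same region as the others, most likely again as a limit. Compound 4 is expected at about 40000 nM, estimated between 15000 nM and 150000 nM, which is an estimated step that the limit leaves unreadable from compound 1 to compound 4.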

Compound 4, half-maximal effective concentration: > 21500 nM
Compound 4: only a limit was reported; the forecaster's own chance of this, stated with the estimate: 80%; the middle value is on the limit's open side.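

Compound 4, like compound 1, compound 2 and compound 3, gives only a limit in this assay, so no step among these compounds can be read: the limit of > 21500 nM in this assay, at which 4 of the 4 values shown sit. The compounds shown leave open whether the groups at this aromatic carbon differ in effect on these cells.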